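The compounds below may be only part of what the source reports. "The series", "measured", "known", "first", "only" and "open" are said of these compounds alone.

Compound 1 `CCOC(=O)C1=Cc2ccccc2OC1(OCc1cn(-c2ccc(F)cc2)nn1)C(F)(F)F`: 8900 nM
Compound 2 `O=C(O)C1=Cc2ccccc2OC1(OCc1cc(-c2ccc(F)cc2)no1)C(F)(F)F`: 168000 nM
Compound 3 `CCOC(=O)C1=Cc2ccccc2OC1(OCc1cc(-c2ccc(Br)cc2)no1)C(F)(F)F`: 71700 nM

These three compounds were tested in a functional assay on DU-145 cells (Homo sapiens) for inhibition, read by MTT assay, with a stated time of 24 h; on this read-out lower numbers stand for stronger inhibition and higher numbers for weaker inhibition. Compound 3 stands second highest of the three numbers: compound 2 gives a higher number, and compound 1 a lower one, both gaps lying beyond the usual scatter of this assay. Compound 4 `CCOC(=O)C1=Cc2ccccc2OC1(OCc1cc(-c2cccc(C(F)(F)F)c2)no1)C(F)(F)F` is not yet measured; it differs from compound 3 in one place, (3-(trifluoromethyl)phenyl in place of 4-bromophenyl on an aromatic carbon). Among the measured compounds shown here, no measured pair shows the effect of this exchange, so the account rests on compound 3 alone. The step from compound 3 to compound 4 is expected to stay within the scatter, in no fixed direction, as a 1.2-fold lower number from compound 3 to compound 4 (0.08 log units; within the scatter). Compound 4 is therefore estimated at 60000 nM in this assay, with a range from 20000 nM to 200000 nM.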

Compound 4, half-maximal inhibitory concentration: 57300 nM
Estimate against measurement, compound 4: 1.0-fold (0.02 log units) above; measured number inside the range.
By their numbers in this assay, from the lowest: compound 1; then compounds 4 and 3 (each within the scatter of the next); then compound 2.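

The exchange of 4-bromophenyl for 3-(trifluoromethyl)phenyl gives a 1.3-fold lower number from compound 3 to compound 4 (0.10 log units; within the scatter) in this assay. This first single-place pair shows that, on this aromatic carbon next to the ring nitrogen, this change of aryl group leaves the number unmoved beyond the scatter, although both the substituent and its place on the phenyl ring differ. No evidence on any measured property bears on this result. Still open, from the compounds shown here alone, is whether an amine or a nitrile on that phenyl ring would move the number beyond the scatter, and the pair cannot separate the substituent from its place.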